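The source may hold more compounds than are shown below. What is called first, only, known or untested is meant among the compounds shown, and "the series" means these compounds.

Working notes on the series. Compound 1 `ClCc1ccc(Cn2cnc3c(Cl)ncnc32)cc1` and compound 2 `ClCc1cccc(Cn2cnc3c(Cl)ncnc32)c1` share the same core and differ only in how the chloromethyl group sits on the benzyl ring. In a functional assay on DU-145 cells (Homo sapiens) for cytotoxicity, read by sulforhodamine B assay, with a stated time of 48 h (on this read-out lower numbers stand for higher toxicity in this test and higher numbers for lower toxicity in this test), compound 1 gives 36300 nM, and compound 2 gives 51300 nM; the two numbers lie within the scatter of each other, so no order between them is claimed. Compound 3 `ClCc1cccc(Cn2cnc3c(Cl)nc(Cl)nc32)c1` is not yet measured; it differs from compound 2 by chloro in place of hydrogen on an aromatic carbon. Going by the values given here, no measured pair shows this change, so no step is known. The step from a 1.3-fold lower number from compound 2 to compound 3 (0.11 log units; within the scatter) is expected to stay within the scatter. Compound 3 is therefore estimated at 40000 nM, with a range from 15000 nM to 100000 nM.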

Compound 3, concentration lethal to 50% of the cells: 5620 nM
Beside the measured number, compound 3's estimate is 7.1-fold (0.85 log units) above it; the measured number lies below the stated range.
By their numbers in this assay, from the lowest: compound 3; then compounds 1 and 2 (each within the scatter of the next).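

In this assay chloro in place of hydrogen on the aromatic carbon between two ring nitrogen atoms brings a 9.1-fold lower number from compound 2 to compound 3 (0.96 log units; beyond the scatter) while the placement of the chloromethyl group, compound 1 against compound 2, showed no order. This position on the shared core is thus the first place in the series where one change moves the number beyond the scatter. No measured evidence bears on the reason for this step. Going by these compounds, whether an amine or a methoxy group at this position moves the number likewise stays open, as does whether the chloro step holds with the chloromethyl group placed as in compound 1.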